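From 3-fluorophenyl to 3-methoxyphenyl: a small expected step

This account rests on a few compounds, and the source may have more. Where it says the series, first, only, none or still open, it means among the compounds named here.

compound 1 `CC1=C(/C=C/C(=O)/C=C/c2cccc(F)c2)C(C)(C)CCC1`: 18700 nM
compound 2 `CC1=C(/C=C/C(=O)/C=C/c2cccc(F)c2)C(C)(C)CCC1O`: 16000 nM

In a functional assay on PC-3 cells (Homo sapiens) for cytotoxicity, read by MTT assay, with a stated time of 72 h (a higher number here means a weaker inhibitor, a lower number a stronger inhibitor), compound 2 gives 16000 nM, which lies within the scatter of compound 1. Compound 3 `COc1cccc(/C=C/C(=O)/C=C/C2=C(C)C(O)CCC2(C)C)c1` carries methoxy in place of fluoro on an aromatic carbon, (methoxy in place of fluoro on an aromatic carbon). For the measured compounds named here, the only measured step, a 1.2-fold lower number from compound 1 to compound 2 (0.07 log units; within the scatter), put hydroxy in place of hydrogen on a saturated ring carbon and stayed within the scatter. Going by the values given here, no measured step tests the aromatic change itself, so the estimate rests on the value of compound 2 and its range is kept wide. The expected size is a 1.1-fold lower number from compound 2 to compound 3 (0.03 log units; within the scatter), with no shift beyond the scatter foreseen. For compound 3 the estimated value is 15000 nM, with an expected range of 6500 nM to 35000 nM.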

Compound 3, half-maximal inhibitory concentration: 6500 nM
Compound 3: the middle estimate sits 2.3-fold (0.36 log units) above what was measured; low and high end bracket the measured number.
By their numbers in this assay, from the lowest: compound 3; then compounds 2 and 1 (each within the scatter of the next).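

In this assay the aromatic position responded where the saturated ring carbon had not: methoxy in place of fluoro gave a 2.5-fold lower number from compound 2 to compound 3 (0.39 log units; beyond the scatter) and so moved the number beyond the scatter, unlike the hydroxy change with a 1.2-fold lower number from compound 1 to compound 2 (0.07 log units; within the scatter). For the compounds shown here, the step is modest, but 3-fluorophenyl to 3-methoxyphenyl is the first change here to register at all. Nothing available explains this difference.

The compounds shown leave open whether an ethoxy or an amine at this place would do the same, and whether methoxy has this effect on the core of compound 1, which lacks the hydroxy.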